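From tert-butoxycarbonyl to pyrimidin-2-yl on a ring nitrogen

The compounds below may be only part of what the source reports. "The series", "measured", "known", "first", "only" and "open" are said of these compounds alone.

- compound 1 `CN1CCN(c2cc(C(F)(F)F)nc(SCc3ccc(C(F)(F)F)cc3)n2)CC1` gives 15800 nM
- compound 2 `CCN1CCN(c2cc(C(F)(F)F)nc(SCc3ccc(C(F)(F)F)cc3)n2)CC1` gives 25600 nM
- compound 3 `CC(C)(C)OC(=O)N1CCN(c2cc(C(F)(F)F)nc(SCc3ccc(C(F)(F)F)cc3)n2)CC1` gives 22200 nM

All three values come from a functional assay on MGC-803 cells (Homo sapiens) for inhibition, read by MTT assay, with a stated time of 72 h (a lower number here means a stronger inhibitor, a higher number a weaker inhibitor), and the compounds differ only in the group on an amine nitrogen in a ring. Compound 3 gives 22200 nM and cannot be ranked against the other two: the gaps are a 1.4-fold higher number from compound 1 to compound 3 (0.15 log units; within the scatter) and a 1.2-fold lower number from compound 2 to compound 3 (0.06 log units; within the scatter) and neither exceeds the usual scatter.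

The next step leads to compound 4 `FC(F)(F)c1ccc(CSc2nc(N3CCN(c4ncccn4)CC3)cc(C(F)(F)F)n2)cc1` with pyrimidin-2-yl in place of tert-butoxycarbonyl on an amine nitrogen in a ring. All three measured steps bear on this change, since each swaps the group on that same nitrogen. Besides the two above, there is a 1.6-fold higher number from compound 1 to compound 2 (0.21 log units; within the scatter) and so no exchange so far has moved the number beyond the scatter. One caution applies: none of the three measured compounds carries an aromatic ring at this place, so these steps are only a loose guide.

No step beyond the scatter is therefore expected in this assay for this change. The expected step is a 1.2-fold lower number from compound 3 to compound 4 (0.09 log units; within the scatter) as an estimate only. For compound 4 the expected value is 18000 nM with an estimated range from 7000 nM to 40000 nM as the likely span.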

Compound 4, half-maximal inhibitory concentration: 35200 nM
Compound 4: middle estimate off by 2.0-fold (0.29 log units), on the low side; measured number inside the range.
By their numbers in this assay, from the lowest: compounds 1, 3, 2 and 4 (each within the scatter of the next, the first and the last beyond it).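

Pyrimidin-2-yl is the first aromatic ring on this ring nitrogen, and in this assay the swap from tert-butoxycarbonyl gives a 1.6-fold higher number from compound 3 to compound 4 (0.20 log units; within the scatter) while the swap from ethyl gives a 1.4-fold higher number from compound 2 to compound 4 (0.14 log units; within the scatter) so neither comparison separates compound 4 from the compound it is set against. Within the data shown here, the new feature is the comparison with the methyl group, which gives a 2.2-fold higher number from compound 1 to compound 4 (0.35 log units; beyond the scatter) and is the first exchange on this nitrogen to pass beyond the scatter, though only modestly and only for this one pair. An aromatic ring at this place therefore brings no clear gain in this assay over the three non-aromatic groups, and the data shown offer no explanation for the modest gap to compound 1.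

With only one aromatic ring in the set, the compounds shown cannot separate the effect of having a ring at this place from the effect of the nitrogen atoms within it, a question that a plain phenyl ring would address. They also leave open how a bare hydrogen on this nitrogen, or a longer chain ending in a carboxylic acid, would compare with the small methyl group of compound 1.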